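Halogen Shift on a Hydroxyethoxy Core: Expected Cytotoxicity

A few compounds are considered here, and "the series" means these few. Any claim that something is new, unique, unknown or untested is made for them only; others in the source may bear on it.

Measured compounds:
compound 1 `COc1ccccc1Oc1c(N)nc(-c2ccc(Br)cc2)nc1Cl`: 14 nM
compound 2 `COc1ccccc1Oc1c(N)nc(-c2cccc(I)c2)nc1Cl`: 4660 nM
compound 3 `COc1ccccc1Oc1c(N)nc(-c2ccc(Br)cc2)nc1OCCO`: 4400 nM

In a functional assay on SK-MEL-28 cells (Homo sapiens) for cytotoxicity, read by CCK-8 assay, with a stated time of 24 h (on this read-out lower numbers stand for stronger inhibition and higher numbers for weaker inhibition), compound 1 gives 14 nM. Compound 2 carries the change (3-iodophenyl in place of 4-bromophenyl on an aromatic carbon), and the step is a 330-fold higher number from compound 1 to compound 2 (2.52 log units; beyond the scatter). Compound 3 has a different core, (2-hydroxyethoxy in place of chloro on an aromatic carbon), and that step is a 310-fold higher number from compound 1 to compound 3 (2.50 log units; beyond the scatter).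

Compound 4 `COc1ccccc1Oc1c(N)nc(-c2cccc(I)c2)nc1OCCO` is not yet measured. It differs from compound 3 by 3-iodophenyl in place of 4-bromophenyl on an aromatic carbon. Among the compounds with values here, this is the same kind of change as the one from compound 1 to compound 2, but the surroundings differ: in compound 3 the carbon is meta to a 2-hydroxyethoxy group and para to a 2-methoxyphenoxy group, whereas in compound 1 it is meta to a chloro group and para to a group of 9 heavy atoms.

Because the earlier step of a 330-fold higher number from compound 1 to compound 2 (2.52 log units; beyond the scatter) was large, compound 4 is expected to give a higher number than compound 3, estimated as a 4.5-fold higher number from compound 3 to compound 4 (0.66 log units; beyond the scatter), though a smaller step than before since compound 3 already gives 4400 nM. The estimate for compound 4 is 20000 nM, between 5000 nM and 100000 nM, with a real chance that only a limit is reported.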

Compound 4, half-maximal inhibitory concentration: 11200 nM
Beside the measured number, compound 4's estimate is 1.8-fold (0.25 log units) above it; the measured number falls inside the stated range.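

In this assay, 3-iodophenyl in place of 4-bromophenyl on the core of compound 3 gives a 2.5-fold higher number from compound 3 to compound 4 (0.41 log units; beyond the scatter), a much smaller step than on the core of compound 1: the same change on two cores in this assay, a 330-fold higher number (2.52 log units; beyond the scatter) from compound 1 to compound 2 and a 2.5-fold higher number (0.41 log units; beyond the scatter) from compound 3 to compound 4, 130-fold (2.12 log units) apart, beyond the scatter of two such steps

Likewise, with 3-iodophenyl in place, 2-hydroxyethoxy in place of chloro gives a 2.4-fold higher number from compound 2 to compound 4 (0.38 log units; beyond the scatter), far less than the same change with 4-bromophenyl in place: the same change on two cores in this assay, a 310-fold higher number (2.50 log units; beyond the scatter) from compound 1 to compound 3 and a 2.4-fold higher number (0.38 log units; beyond the scatter) from compound 2 to compound 4, 130-fold (2.12 log units) apart, beyond the scatter of two such steps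

Both changes raise the number on both cores, but the size of neither carries over, and these four compounds do not show why.

As far as these compounds go, it remains open whether a 4-iodophenyl or 3-bromophenyl group would keep the low number of compound 1. From the compounds shown here alone, it also remains open how an amine or a methoxy group in place of chloro would fare.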